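Dropping one fluorine from a weakly cytotoxic antifolate

This account rests on a few compounds, and the source may have more. Where it says the series, first, only, none or still open, it means among the compounds named here.

Measured compounds:
Compound 1 `Nc1nc(N)c(CCCN(Cc2ccc(NC(CCC(=O)O)C(=O)O)cc2)c2cc(F)c(F)cc2[N+](=O)[O-])c(O)n1`: > 100000 nM
Compound 2 `Nc1nc(N)c(CCCNc2cc(F)c(F)cc2[N+](=O)[O-])c(O)n1`: 97000 nM
Compound 3 `CC(C)(C)OC(=O)CCC(Nc1ccc(CN(CCCc2c(N)nc(N)nc2O)c2cc(F)cc(F)c2[N+](=O)[O-])cc1)C(=O)OC(C)(C)C`: 13000 nM

In a functional assay on CCRF-CEM cells (Homo sapiens) for cytotoxicity, in the absence of a further agent (on this read-out higher numbers stand for weaker inhibition and lower numbers for stronger inhibition), compound 1 gives only a limit, > 100000 nM, so its value is not a number but the edge of what the assay reports (the limit of > 100000 nM in this assay, at which 1 of the 3 values shown sits). Compound 2, which lacks the benzyl glutamate arm, gives 97000 nM in this assay. Compound 3, the di-tert-butyl ester with a different arrangement of the two fluoro groups, gives 13000 nM in this assay, the lowest of the three numbers shown.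

Compound 4 `Nc1nc(N)c(CCCN(Cc2ccc(NC(CCC(=O)O)C(=O)O)cc2)c2cc(F)ccc2[N+](=O)[O-])c(O)n1` is the next compound to be measured in this assay. It differs from compound 1 by hydrogen in place of fluoro on an aromatic carbon. For the measured compounds named here, no step between measured compounds describes this change, so the account rests on the values alone. Compound 1 sits at the limit, and a single hydrogen in place of fluoro is not expected to carry the cytotoxicity far from it. For compound 4 the expected value in this assay is 120000 nM, within 30000 nM to 400000 nM, a step that the limit leaves unreadable from compound 1 to compound 4 that is expected to lie within the scatter; there is a fair chance that only a limit is reported again.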

Compound 4, half-maximal inhibitory concentration: > 100000 nM
Compound 4 gave a limit, no number; the forecaster's own chance of this, stated with the estimate: 55%; the middle value is on the limit's open side.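

In this assay compound 4 gives > 100000 nM, which is a limit and not a number. Compound 1 also gives only a limit, so no step from compound 1 to compound 4 can be read: the limit of > 100000 nM in this assay, at which 2 of the 4 values shown sit.

The compounds shown leave open whether hydrogen in place of this fluoro group changes cytotoxicity at all.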